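This account rests on a few compounds, and the source may have more. Where it says the series, first, only, none or still open, it means among the compounds named here.

Three compounds share one core and differ only in the group on the sulfonyl sulfur. Compound 1 `O=S(=O)(Nc1ccc2oc(-c3ccccc3)nc2c1)c1ccccc1O` carries 2-hydroxyphenyl there, and in an assay on isolated protein for inhibition of malate dehydrogenase, mitochondrial (Sus scrofa), with stated times of 45 min and 30 min (on this read-out higher numbers stand for weaker inhibition and lower numbers for stronger inhibition), compound 1 gives > 63000 nM, which is a limit of the assay rather than a number. Compound 2 `O=S(=O)(Nc1ccc2oc(-c3ccccc3)nc2c1)c1ccc(Cl)c(Cl)c1` carries 3,4-dichlorophenyl, and in this assay compound 2 gives > 63000 nM, again a limit. Compound 3 `Cc1ccccc1S(=O)(=O)Nc1ccc2oc(-c3ccccc3)nc2c1` carries 2-methylphenyl, and in this assay compound 3 gives > 63000 nM, also a limit. Compound 3 thus stands where every measured value stands, at the limit of > 63000 nM in this assay, at which 3 of the 3 values shown sit. The steps between these compounds, a step that the two limits leave unreadable from compound 1 to compound 2, a step that the two limits leave unreadable from compound 1 to compound 3 and a step that the two limits leave unreadable from compound 2 to compound 3, cannot be read for size because each end is a limit. Compound 4 `O=S(=O)(Nc1ccc2oc(-c3ccccc3)nc2c1)c1ccccc1C(F)(F)F` has not yet been measured; it differs from compound 3 by trifluoromethyl in place of methyl on an aromatic carbon. Within the data shown here, no measured step bears readably on this change, so neither a size nor a direction can be drawn from them. Because compound 3 gives > 63000 nM as a limit, compound 4 is expected to sit near that same limit, an estimated step that the limit leaves unreadable from compound 3 to compound 4. The value estimated for compound 4 is 80000 nM, within 20000 nM to 300000 nM.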

Compound 4, half-maximal inhibitory concentration: > 63000 nM
Compound 4: no number, only a limit (the forecaster's own chance of this, stated with the estimate: 80%); the middle value is on the limit's open side.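

No step to compound 4, from compound 1 or from compound 3, can be read for size, since both ends of each step are limits and not numbers: the limit of > 63000 nM in this assay, at which 4 of the 4 values shown sit.

The compounds shown leave open whether any group on the sulfonyl sulfur of the shared core gives a readable number in this assay.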